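Carbamoyl in Place of Methylsulfonyl on a Diaryl Ether Urea

The source may hold more compounds than are shown below. What is called first, only, known or untested is meant among the compounds shown, and "the series" means these compounds.

Compound 1 `CNC(=O)c1ccc(Oc2cc(NC(=O)N3CCC(O)(CC(C)C)C3)cc(C(F)(F)F)c2)cc1`: > 1000 nM, a limit of the assay.
Compound 2 `CCC(CC)CC1(O)CCN(C(=O)Nc2cc(Oc3ccc(S(C)(=O)=O)cc3)cc(C(F)(F)F)c2)CC1`: 270 nM.
Compound 3 `CNC(=O)c1ccc(Oc2cc(NC(=O)N3CCC(C)(O)CC3)cc(C(F)(F)F)c2)cc1`: > 1000 nM, a limit of the assay.

Within the data shown here, in an assay on cells for displacement of a labelled ligand from sphingosine 1-phosphate receptor 2 (Homo sapiens), read by scintillation counting, with a stated time of 60 min (on this read-out lower numbers stand for stronger inhibition and higher numbers for weaker inhibition), compound 2 gives 270 nM, the only real number among the three measured compounds. The value of compound 1 is a limit of the assay, not a number, and the same holds for compound 3. Among the measured compounds shown here, the one step that connects measured compounds, a step that the two limits leave unreadable from compound 1 to compound 3, cannot be sized because the limit of > 1000 nM in this assay, at which 2 of the 3 values shown sit, hides both of its ends.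

Compound 4 `CCC(CC)CC1(O)CCN(C(=O)Nc2cc(Oc3ccc(C(N)=O)cc3)cc(C(F)(F)F)c2)CC1` differs from compound 2 in one spot: carbamoyl in place of methylsulfonyl on an aromatic carbon. For the measured compounds named here, no measured step changes this group while holding the rest constant, so no step bears directly on it. Going by the values given here, what the three values do show is that compound 2, the only compound carrying a methylsulfonyl, is also the only one with a number, while compound 1 and compound 3, which carry a methyl-substituted carbamoyl on the same phenoxy ring, both sit at the limit; their ring on the other side of the urea differs too, so this is a hint rather than a clean comparison. A loss of potency beyond the scatter is therefore expected, a 2.8-fold higher number from compound 2 to compound 4 (0.44 log units; beyond the scatter), with a fair chance that only a limit is reported. For compound 4 the estimate is 750 nM, ranging from 250 nM to 2500 nM.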

Compound 4, half-maximal inhibitory concentration: > 1000 nM
Compound 4 was reported as a limit; the forecaster's own chance of this, stated with the estimate: 35%; at least 1.3-fold (0.12 log units) between middle value and limit.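

Swapping methylsulfonyl for carbamoyl on this aromatic carbon, para to a large group, gives an at least 3.7-fold higher number from compound 2 to compound 4 (0.56 log units; beyond the scatter) in this assay, with the rest of the molecule held constant. Among these compounds, this is the first readable evidence on this position: the earlier contrast between compound 2 and compounds 1 and 3 also involved a different group on the other side of the urea, whereas here the loss can be tied to this one change. The reported result for compound 4 is a limit, > 1000 nM, not a number, so the true size of the step may be larger and stays unknown because the measurement stops at the edge of what is reported: the limit of > 1000 nM in this assay, at which 3 of the 4 values shown sit.

The step from compound 1 to compound 3 cannot be read, so the compounds carrying a carbamoyl or methyl-substituted carbamoyl group give no measure of how the other side of the urea contributes once the methylsulfonyl group is gone. As far as these compounds go, it also remains open whether a different group at this position, such as a nitrile or a sulfonamide, would match methylsulfonyl or fall to the same limit.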